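The compounds below may be only part of what the source reports. "The series", "measured", "known", "first", "only" and "open" are said of these compounds alone.

Four compounds share one core and differ in two places. Compound 2 `O=C(Cn1c(=O)oc2cc(Cl)ccc21)NCc1ccco1` carries chloro on the core and a furan-2-yl group on the saturated chain carbon bound to the amide-type nitrogen. In an ADME assay on RAW264.7 cells (Mus musculus) for cytotoxicity, read by MTT assay, with a stated time of 72 h, tested at 100 uM (a lower number here means a weaker effect, a higher number a stronger effect of the compound at the concentration tested), compound 2 gives 50.3%. Compound 1 `O=C(Cn1c(=O)oc2cc(Cl)ccc21)NCc1cccs1` differs from compound 2 by thiophen-2-yl in place of furan-2-yl on a saturated chain carbon bound to an amide-type nitrogen, and in this assay compound 1 gives 53.6%; the step is a number 3.3 percentage points higher from compound 2 to compound 1 (within the scatter). Compound 3 `O=C(Cn1c(=O)oc2cc([N+](=O)[O-])ccc21)NCc1ccco1` differs from compound 2 in the core, by nitro in place of chloro on an aromatic carbon, and in this assay compound 3 gives 60.1%; that step is a number 9.8 percentage points higher from compound 2 to compound 3 (within the scatter). Compound 4 `O=C(Cn1c(=O)oc2cc([N+](=O)[O-])ccc21)NCc1cccs1` has not yet been measured. For the measured compounds named here, it differs from compound 3 by thiophen-2-yl in place of furan-2-yl on a saturated chain carbon bound to an amide-type nitrogen, the same change as the one between compound 2 and compound 1, now made on the core that carries nitro rather than chloro; the place of the change is the same in both pairs. The expected step is a number 2.9 percentage points higher from compound 3 to compound 4 (within the scatter) because the same change earlier gave a number 3.3 percentage points higher from compound 2 to compound 1 (within the scatter). On that basis compound 4 is expected to give about 63% in this assay, with a likely range from 52% to 74%.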

Compound 4, a percentage reported as inhibition, at one concentration (the size of the read-out at that concentration, not a potency): 41%
Beside the measured number, compound 4's estimate is 22 percentage points above it, and the stated range ends above it.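

In this assay, thiophen-2-yl in place of furan-2-yl on the core carrying nitro gives a number 19.1 percentage points lower from compound 3 to compound 4 (beyond the scatter), so this change does not carry over unchanged from the core carrying chloro: the same change on two cores in this assay, a number 3.3 percentage points higher (within the scatter) from compound 2 to compound 1 and a number 19.1 percentage points lower (beyond the scatter) from compound 3 to compound 4, 22.4 percentage points apart, beyond the scatter of two such steps. Seen from the other place, nitro in place of chloro with thiophen-2-yl held fixed gives a number 12.6 percentage points lower from compound 1 to compound 4 (beyond the scatter), which shows that the outcome of each change depends on the group in the other place: the same change on two cores in this assay, a number 9.8 percentage points higher (within the scatter) from compound 2 to compound 3 and a number 12.6 percentage points lower (beyond the scatter) from compound 1 to compound 4, 22.4 percentage points apart, beyond the scatter of two such steps. This rests on a single set of four compounds at one tested concentration, so it shows that a step measured on one core cannot be assumed on the other here, but not why the two cores differ or whether the same holds elsewhere in the series.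

The compounds shown leave open how the furan-2-yl and thiophen-2-yl groups would behave with an amine or a carboxylic acid on the core in place of nitro or chloro. They also leave open what a phenyl ring or a longer chain would do in place of the (furan-2-yl)methyl and (thiophen-2-yl)methyl groups.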